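The source may hold more compounds than are shown below. What is called first, only, known or untested is meant among the compounds shown, and "the series" means these compounds.

Measured so far:
Compound 1, `COc1ccc(Cl)cc1C(=O)NCCC1CCN(S(=O)(=O)NC(=O)NC[C@@H]2C[C@@H]3CC[C@@H]2O3)CC1`, gives 30% in a functional assay on the whole organism (blood) with Rattus norvegicus as the target, with stated times of 24 h and 1 h, at a dose of 5 mg/kg by the intraperitoneal route; on this read-out lower numbers stand for a weaker effect and higher numbers for a stronger effect at the one dose given.
Compound 2, `O=C(NC[C@@H]1C[C@@H]2CC[C@@H]1O2)NS(=O)(=O)N1CCC(CCNC(=O)c2cccc3c2OCCO3)CC1`, gives 15%.
Compound 3, `COc1ncccc1C(=O)NCCC1CCN(S(=O)(=O)NC(=O)NC[C@@H]2C[C@@H]3CC[C@@H]2O3)CC1`, gives 34%.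

Compound 3 holds the highest of the three numbers. Its nearest neighbour is compound 1, and that gap is within the scatter, so no order between compound 3 and compound 1 can be read from it. Compound 2 sits furthest away: the step of a number 19 percentage points higher from compound 2 to compound 3 (beyond the scatter) is modest and beyond the scatter, as is a number 15 percentage points lower from compound 1 to compound 2 (beyond the scatter) in the opposite direction, while a number 4 percentage points higher from compound 1 to compound 3 (within the scatter) stays within the scatter.

Compound 4, `COc1ncccc1C(=O)NCCC1CCN(S(=O)(=O)NC(=O)NCC2CCCO2)CC1`, differs from compound 3 in one place: a group of 5 heavy atoms (4 carbon, 1 oxygen; one five-membered non-aromatic ring with 1 hetero atom) in place of a group of 7 heavy atoms (6 carbon, 1 oxygen; 2 five-membered non-aromatic rings with 1 hetero atom each), on a saturated chain carbon bound to an amide-type nitrogen. Going by the values given here, every measured step so far changes the group on the carbonyl carbon; none touches the saturated chain carbon bound to the amide-type nitrogen, so no measured step bears directly on this change. The expectation for compound 4 therefore rests only on the value of compound 3 and on the spread of the three numbers, which sit in a fairly narrow band. Compound 4 is expected to stay near that band, and the step of a number 6 percentage points lower from compound 3 to compound 4 (within the scatter) is expected to remain within the scatter, though with considerable uncertainty. Compound 4 is estimated at 28%, with a range from 10% to 46%.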

Compound 4, a percentage reported as activity, at one dose (the size of the read-out at that dose, not a potency): 16%
For compound 4 the middle estimate is 12 percentage points above the measured one, and the stated range covers the measured number.
By their numbers in this assay, from the lowest: compounds 2 and 4 (each within the scatter of the next); then compounds 1 and 3 (each within the scatter of the next).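

Going by these compounds alone, compound 4 gives the first reading at the saturated chain carbon bound to an amide-type nitrogen: with the 2-methoxypyridin-3-yl group held fixed, oxolan-2-yl in place of the group of 7 heavy atoms gives a number 18 percentage points lower from compound 3 to compound 4 (beyond the scatter) in this assay. Within the data shown here, the read-out therefore responds to this position as well as to the group on the carbonyl carbon, the only place changed in the earlier steps, and the single-ring oxolan-2-yl group does not match the two-ring group it replaces here. Nothing measured in this set gives a reason for the step, which therefore stands as an observation only.

The change removes a ring, heavy atoms and 3 defined stereocentres together, so these compounds cannot show which of these matters, or whether a cyclopentyl group, a tetrahydropyran-2-yl ring, a longer alkyl chain or an amine at this position would read differently. They also leave open whether oxolan-2-yl would give a step of similar size with 5-chloro-2-methoxyphenyl or 2,3-dihydro-1,4-benzodioxin-5-yl on the carbonyl carbon.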